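The compounds below may be only part of what the source reports. "The series", "measured", "known", "first", "only" and "open" are said of these compounds alone.

In a functional assay on MCF7 cells (Homo sapiens) for antiproliferative activity, read by sulforhodamine B assay, with a stated time of 48 h (on this read-out lower numbers stand for stronger inhibition and higher numbers for weaker inhibition), compound 3 `CC(C)C(=O)Nc1cccc(S(=O)(=O)Oc2ccccc2C(C)C)c1` gives 13000 nM. Among the three measured compounds its number is the second highest: compound 1 `CCC(=O)Nc1cccc(S(=O)(=O)Oc2ccccc2C(C)C)c1` gives 14000 nM, and compound 2 `CCCCCC(=O)Nc1cccc(S(=O)(=O)Oc2ccccc2C(C)C)c1` gives 12000 nM. The step of a 1.1-fold lower number from compound 1 to compound 3 (0.03 log units; within the scatter) and the step of a 1.1-fold higher number from compound 2 to compound 3 (0.03 log units; within the scatter) both lie within the scatter, as does a 1.2-fold lower number from compound 1 to compound 2 (0.07 log units; within the scatter). Compound 4 `CC(C)c1ccccc1OS(=O)(=O)c1cccc(NC(=O)C(C)(C)C)c1` differs from compound 3 by methyl in place of hydrogen on a saturated chain carbon bound to a carbonyl carbon and two saturated chain carbons. The measured step that bears most directly on this change is the one that also placed a methyl on the saturated chain carbon bound to the carbonyl carbon, namely a 1.1-fold lower number from compound 1 to compound 3 (0.03 log units; within the scatter), which stayed within the scatter. The exchange of pentyl for isopropyl in a 1.1-fold higher number from compound 2 to compound 3 (0.03 log units; within the scatter) likewise stayed within the scatter. Within the data shown here, no step among the three measured compounds moved this assay beyond the scatter, so no step beyond the scatter is expected in this assay from compound 3 to compound 4. The estimate for compound 4 is 13000 nM, with a range of 6000 nM to 28000 nM, which means an expected step of no change at the digits printed from compound 3 to compound 4 (within the scatter).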

Compound 4, half-maximal inhibitory concentration: 14000 nM
Compound 4: the middle estimate sits 1.1-fold (0.03 log units) below what was measured; measured number inside the range.
By their numbers in this assay, from the lowest: compounds 2, 3, 1 and 4 (each within the scatter of the next).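

In this assay, methyl in place of hydrogen on a saturated chain carbon bound to a carbonyl carbon and two saturated chain carbons, which turns isopropyl into tert-butyl, gives a 1.1-fold higher number from compound 3 to compound 4 (0.03 log units; within the scatter), so this further methyl on that carbon leaves the reading as unmoved as the first one did. Tert-butyl in place of pentyl gives a 1.2-fold higher number from compound 2 to compound 4 (0.07 log units; within the scatter) and tert-butyl in place of ethyl gives no change at the digits printed from compound 1 to compound 4 (within the scatter), so all four groups on the carbonyl carbon, straight or branched, now read alike within the scatter. Nothing available offers a reason for this sameness.

On these data alone, whether a group of another kind on the carbonyl carbon, such as an amine, a carboxylic acid or a phenyl ring, would move the number beyond the scatter remains open. So does the effect of any change elsewhere on the shared core.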